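The compounds below may be only part of what the source reports. "The series", "measured", "known", "first", "only" and "open" are said of these compounds alone.

Compound 3 `Cc1ccc(CCCN2CCc3nc(C)c([C@H](OC(C)(C)C)C(=O)O)c(-c4cc(F)c5c(c4C)CCCO5)c3C2)cc1` is the starting point, and in an ADME assay on MT2 cells (Homo sapiens) for cytotoxicity, read by XTT assay, with a stated time of 4 days (a lower number here means that less compound is tolerated, a higher number that more compound is tolerated), compound 3 gives > 40000 nM, which is a limit of the measurement and not a number. Its two neighbours stand no differently. Compound 1 `Cc1nc2c(c(-c3cc(F)c4c(c3C)CCCO4)c1[C@H](OC(C)(C)C)C(=O)O)CN(CCCc1ccccc1F)CC2` gives in this assay > 40000 nM, again a limit. Compound 2 `Cc1nc2c(c(-c3cc(F)c4c(c3C)CCCO4)c1[C@H](OC(C)(C)C)C(=O)O)CN(CCCc1ccccc1)CC2` gives in this assay > 40000 nM, likewise a limit. The three steps that connect them, a step that the two limits leave unreadable from compound 1 to compound 2, a step that the two limits leave unreadable from compound 1 to compound 3 and a step that the two limits leave unreadable from compound 2 to compound 3, therefore cannot be read for size in either direction, since (the limit of > 40000 nM in this assay, at which 3 of the 3 values shown sit).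

Compound 4 `Cc1ccccc1CCCN1CCc2nc(C)c([C@H](OC(C)(C)C)C(=O)O)c(-c3cc(F)c4c(c3C)CCCO4)c2C1` has not yet been tested. It differs from compound 3 by 2-methylphenyl in place of 4-methylphenyl on a saturated chain carbon, three bonds along the chain from an amine nitrogen in a ring. For the measured compounds named here, no measured step bears on such a change. Going by the values given here, every value so far sits at the same limit, and there is nothing to say that moving the methyl around the phenyl ring would bring the tolerated concentration within reach of the assay. For compound 4 the author therefore expects no readable step, a number no higher from compound 3 to compound 4 (the limit leaves the size open), and estimates a tolerated concentration near 40000 nM, with a range from 20000 nM to 80000 nM, most likely reported once more only as a limit.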

Compound 4, half-maximal cytotoxic concentration: > 40000 nM
Compound 4: no number, only a limit; the forecaster's own chance of this, stated with the estimate: 85%; the middle value sits exactly at the limit.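

The steps joining compound 4 to compound 1, compound 2 and compound 3 cannot be read for size, since all four compounds stand at one limit: the limit of > 40000 nM in this assay, at which 4 of the 4 values shown sit.

The compounds shown leave open at what concentration any of them would reach the half-maximal read-out in this assay, and whether these changes alter it at all.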